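This account rests on a few compounds, and the source may have more. Where it says the series, first, only, none or still open, it means among the compounds named here.

Antiproliferative read-out in a functional assay on BGC-823 cells (Homo sapiens) for antiproliferative activity, read by MTT assay, tested at 1 uM (on this read-out higher numbers stand for a stronger effect at the one concentration tested and lower numbers for a weaker effect), measured compounds:

compound 1 `COc1cc(C(=O)N/N=C/c2ccccc2C(F)(F)F)cc(OC)c1OC`: 22.1%
compound 2 `COc1cc(C2=NN(C(C)=O)C(c3ccc(F)c(F)c3)O2)cc(OC)c1OC`: 18.3%
compound 3 `COc1cccc(/C=N/NC(=O)c2cc(OC)c(OC)c(OC)c2)c1OC`: -0.1%

Compound 2 and compound 1 lie within the usual scatter of each other; compound 3 sits clearly below compound 2, beyond the scatter. For the measured compounds named here, no pair of measured compounds differs in only one place, so no single step is known.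

Compound 4 `COc1cc(C2=NN(C(C)=O)C(c3cc(Cl)cc(Cl)c3)O2)cc(OC)c1OC` is not yet measured. Its change from compound 2: 3,5-dichlorophenyl in place of 3,4-difluorophenyl on a saturated ring carbon. Going by the values given here, nothing among the measured compounds speaks for this exchange on the saturated ring carbon, so no step beyond the scatter in this assay is expected in either direction. Compound 4 is estimated at 18% (5% to 32%), which means an expected step of a number 0.3 percentage points lower from compound 2 to compound 4 (within the scatter).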

Compound 4, a percentage reported as inhibition, at one concentration (the size of the read-out at that concentration, not a potency): 0%
For compound 4 the middle estimate is 18 percentage points above the measured one; the measured number lies below the stated range.
By their numbers in this assay, from the lowest: compounds 3 and 4 (each within the scatter of the next); then compounds 2 and 1 (each within the scatter of the next).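

In this assay, for the compounds shown here, the exchange of 3,4-difluorophenyl for 3,5-dichlorophenyl on the saturated ring carbon gives a number 18.3 percentage points lower from compound 2 to compound 4 (beyond the scatter) as the first single-place step. This position therefore responds to the aryl group it carries, and the shared core alone does not hold the read-out. No measurement at hand accounts for the step.

Halogen and substitution pattern change together here, so the compounds shown cannot separate them. A 3,4-dichlorophenyl or 3,5-difluorophenyl group on this carbon would bear on that question.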